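The source may report more compounds than this note shows. Statements on the series, on what has been measured and on what is new or still open speak of the compounds shown alone.

Of the compounds shown here, three built on one shared core have been tested in a functional assay on the whole organism for inhibition, with Rattus norvegicus as the target, at a dose of 10 mg/kg by the oral route; on this read-out lower numbers stand for less inhibition and higher numbers for more inhibition at the one dose given (going by the name of the read-out). Compound 1 `COc1cccc([C@H]2O[C@H](CC(=O)NCCCCC(=O)O)C(=O)N(CC(C)(C)CO)c3ccc(Cl)cc32)c1OC` gives 50% in this assay. Compound 2 `COc1cccc([C@H]2O[C@H](CC(=O)N3CCC(CC(=O)O)CC3)C(=O)N(CC(C)(C)COC(=O)C(C)C)c3ccc(Cl)cc32)c1OC` gives 34% in this assay, and compound 3 `COc1cccc([C@H]2O[C@H](CC(=O)N3CCC(CC(=O)O)CC3)C(=O)N(CC(C)(C)COCC(=O)OC(C)(C)C)c3ccc(Cl)cc32)c1OC` gives 43% in this assay. Going by the values given here, the only step between compounds that differ in a single place is a number 9 percentage points higher from compound 2 to compound 3 (within the scatter), which swaps an ester on an oxygen on a saturated carbon and stays within the scatter. Compound 1 stands above compound 2 by a gap beyond the scatter, while the gap between compound 1 and compound 3 is within the scatter, so those two cannot be told apart.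

Compound 4 `COc1cccc([C@H]2O[C@H](CC(=O)N[C@@H](C)C(=O)O)C(=O)N(CC(C)(C)CO)c3ccc(Cl)cc32)c1OC` is the next candidate. It differs from compound 1 in one place: 1-carboxyethyl in place of 4-carboxybutyl on an amide-type nitrogen. The acid is kept, but it now sits on a shorter chain carrying a defined stereocentre. Among the compounds with values here, no measured step touches this amide-type nitrogen, and the one step that is known changes a different part of the molecule and lies within the scatter, so it gives no direction. With nothing pointing up or down, the step is expected to be small, and the estimated a number 5 percentage points lower from compound 1 to compound 4 (within the scatter) is expected to stay within the scatter. Compound 4 is therefore estimated at 45%, with a likely range from 25% to 65%.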

Compound 4, a percentage reported as inhibition, in the whole organism at one dose (the size of the read-out at that dose, not a potency): 14%
The estimate for compound 4 lay 31 percentage points above the measured number; measured number below the stated range.
By their numbers in this assay, from the lowest: compound 4; then compounds 2, 3 and 1 (each within the scatter of the next, the first and the last beyond it).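

In this assay, going by these compounds alone, the group on the amide-type nitrogen turns out to matter: 1-carboxyethyl in place of 4-carboxybutyl comes with a number 36 percentage points lower from compound 1 to compound 4 (beyond the scatter), the first single-place step to lie beyond the scatter. Both groups carry the carboxylic acid, so keeping the acid on this nitrogen is not enough to hold the read-out at the level of compound 1, and the identity of the chain that carries it makes a clear difference. Two things changed together in this step, since the group went from 7 heavy atoms to 5 and gained a defined stereocentre, and no measurement available here explains the drop or shows how this whole-organism result arises.

The compounds shown cannot separate chain length from the stereocentre, a question that 3-carboxypropyl, 2-carboxyethyl or the mirror-image form of 1-carboxyethyl on the same nitrogen could help to settle. They also leave open whether a longer chain such as 5-carboxypentyl would go beyond compound 1, and what an amine at the end of the 4-carboxybutyl chain, in place of the carboxylic acid, would do.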